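Replacing the pentylcarbonyl chain of compound 1

The compounds below may be only part of what the source reports. "The series", "measured", "known", "first", "only" and "open" are said of these compounds alone.

For the measured compounds named here, in a functional assay on the whole organism for antagonist activity, with Mus musculus as the target (a higher number here means that more compound is needed for the effect, a lower number that less compound is needed), compound 1 (`CCCCCC(=O)NCC(=O)N(C)c1ccc(Cl)cc1C(=O)c1ccccc1Cl`) gives 1.9 mg/kg as the lowest of the three numbers known so far. Compound 2 (`CN1CCN(CC(=O)NCC(=O)N(C)c2ccc(Cl)cc2C(=O)c2ccccc2Cl)CC1`) reaches 59 mg/kg and compound 3 (`NC(C(=O)NCC(=O)Nc1ccc(Cl)cc1C(=O)c1ccccc1)c1ccccc1`) reaches 28 mg/kg in the same test, both clearly higher than compound 1. The unmeasured compound 4 (`CC(NC(=O)CN)C(=O)N(C)c1ccc(Cl)cc1C(=O)c1ccccc1Cl`) carries 1-(((aminomethyl)carbonyl)amino)ethyl in place of ((pentylcarbonyl)amino)methyl on a carbonyl carbon. Going by the values given here, one measured step bears directly on this change. It is a 31-fold higher number from compound 1 to compound 2 (1.49 log units; beyond the scatter), a large step in which 4-methylpiperazin-1-yl replaces butyl and the pentylcarbonyl chain is lost, as it is in compound 4. Among the compounds with values here, compound 3 differs in more than one place, but it also ends in an amino-bearing chain and sits high, and no measured compound goes against this trend. A clear rise is therefore expected, probably smaller than the rise seen for compound 2. The estimated step is a 6.3-fold higher number from compound 1 to compound 4 (0.80 log units; beyond the scatter) in all. For compound 4 the expected value is 12 mg/kg, with an estimated range from 3 mg/kg to 45 mg/kg in this test.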

Compound 4, dose for half-maximal effect: 0.47 mg/kg
Compound 4: the middle estimate sits 26-fold (1.41 log units) above what was measured; the measured number lies below the stated range.
By their numbers in this assay, from the lowest: compound 4; then compound 1; then compound 3; then compound 2.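

The change on the carbonyl carbon gives a 4.0-fold lower number from compound 1 to compound 4 (0.61 log units; beyond the scatter) in this assay and so shows that this position accepts 1-(((aminomethyl)carbonyl)amino)ethyl in place of ((pentylcarbonyl)amino)methyl with no rise in the number. The step of a 31-fold higher number from compound 1 to compound 2 (1.49 log units; beyond the scatter) runs the opposite way, so losing the pentylcarbonyl chain does not by itself raise the number, and the direction of the step depends on the group that enters. Nothing available explains why these two replacements part ways. The compounds shown do not separate the aminomethyl part of the entering group from its ethyl part, so it remains open which of them accounts for the step. From the compounds shown here alone, it also remains open whether a longer chain carrying an amine, or a chain ending in a carboxylic acid, would keep the number this low.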